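A few compounds are considered here, and "the series" means these few. Any claim that something is new, unique, unknown or untested is made for them only; others in the source may bear on it.

Measured so far in a functional assay on Raji cells (Homo sapiens) for antiproliferative activity, read by MTT assay, with a stated time of 72 h; on this read-out lower numbers stand for stronger inhibition and higher numbers for weaker inhibition:
- compound 1 `CN(Cc1nc(C2CCN(Cc3ccc(C#N)cc3)CC2)no1)c1ncc(C(=O)NO)cn1`: 117 nM
- compound 2 `CN(Cc1nc(C2CCN(Cc3ccc(C(F)(F)F)cc3)CC2)no1)c1ncc(C(=O)NO)cn1`: 207 nM

In this assay, within the data shown here, compound 2 gives 207 nM, and its only neighbour is compound 1 at 117 nM. The two values cannot be told apart.

The next compound is compound 3 `CN(Cc1nc(C2CCN(Cc3ccc(F)cc3F)CC2)no1)c1ncc(C(=O)NO)cn1`, with 2,4-difluorophenyl in place of 4-(trifluoromethyl)phenyl on a saturated chain carbon bound to an amine nitrogen in a ring. Among the measured compounds shown here, the one measured step that bears on this change is a 1.8-fold higher number from compound 1 to compound 2 (0.25 log units; within the scatter), which put trifluoromethyl in place of cyano on an aromatic carbon. For the measured compounds named here, that step is small, but it is a single exchange of one group, and no measured compound carries the 2,4-difluorophenyl group. The evidence is therefore thin, and it offers no ground for a direction. No shift beyond the scatter is expected in this assay. The expected step is a 1.3-fold lower number from compound 2 to compound 3 (0.11 log units; within the scatter). For compound 3 the estimated value is 160 nM, with an expected range from 65 nM to 400 nM.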

Compound 3, half-maximal inhibitory concentration: 34.3 nM
The estimate for compound 3 lay 4.7-fold (0.67 log units) above the measured number; measured number outside the range, below it.
By their numbers in this assay, from the lowest: compound 3; then compounds 1 and 2 (each within the scatter of the next).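

In this assay, among these compounds, the aryl group at this position now shows a clear effect: 2,4-difluorophenyl in place of 4-(trifluoromethyl)phenyl gives a 6.0-fold lower number from compound 2 to compound 3 (0.78 log units; beyond the scatter), and 2,4-difluorophenyl in place of 4-cyanophenyl gives a 3.4-fold lower number from compound 1 to compound 3 (0.53 log units; beyond the scatter), whereas the only earlier exchange, a 1.8-fold higher number from compound 1 to compound 2 (0.25 log units; within the scatter), did not separate compound 1 from compound 2. Compound 3 therefore stands apart from the other two, and the position is not indifferent to what the benzyl ring carries, although these two steps are modest and each exchanges a whole substituted aryl group. Nothing available accounts for the lower number of compound 3.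

The compounds shown leave open whether a single fluorine on the benzyl ring would give the same step or whether both fluorines are needed. Also open, on these data alone, is how an unsubstituted benzyl group, a chlorine on the ring or a methoxy group would read in this assay.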